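A few compounds are considered here, and "the series" means these few. Any claim that something is new, unique, unknown or untested is made for them only; others in the source may bear on it.

Series notes. Compound 1 `OC1CCN(c2ccc(-c3ccccc3Cl)nn2)CC1` is the reference for this step. Among the measured compounds shown here, in a functional assay on the whole organism with Mus musculus as the target (a lower number here means that less compound is needed, a higher number that more compound is needed for the effect), compound 1 gives 38 mg/kg, the higher of the two numbers measured so far. Compound 2 `OC1CCN(c2ccc(-c3ccccc3F)nn2)CC1`, in which fluoro replaces chloro on an aromatic carbon, gives 30 mg/kg in this assay; the step of a 1.3-fold lower number from compound 1 to compound 2 (0.10 log units; within the scatter) is within the scatter, so the two compounds cannot be ordered.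

Compound 3 `O=C(OC1CCN(c2ccc(-c3ccccc3Cl)nn2)CC1)C1CC1` carries a different change: cyclopropylcarbonyl in place of hydrogen on an oxygen on a saturated carbon. For the measured compounds named here, the only measured step concerns the halogen on the aromatic ring and says nothing about the hydroxy of the shared core, so no measured step bears on this change, and the expectation rests on compound 1 alone. The step from compound 1 to compound 3 is expected to be no change at the digits printed from compound 1 to compound 3 (within the scatter), with a wide range in either direction. Compound 3 is therefore estimated at 38 mg/kg in this assay, between 15 mg/kg and 100 mg/kg.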

Compound 3, dose for half-maximal effect: 92 mg/kg
Estimate against measurement, compound 3: 2.4-fold (0.38 log units) below; low and high end bracket the measured number.
By their numbers in this assay, from the lowest: compounds 2 and 1 (each within the scatter of the next); then compound 3.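

In this assay, among the compounds shown here, the oxygen on the saturated carbon is the first place where a change moves the number beyond the scatter: going from hydroxy to (cyclopropylcarbonyl)oxy gives a 2.4-fold higher number from compound 1 to compound 3 (0.38 log units; beyond the scatter). The step is modest, and with the hydroxy hydrogen replaced, compound 3 still gives a measured dose of 92 mg/kg, so this position tolerates a cyclopropylcarbonyl group with only a limited shift in the number. No measurement at hand speaks to the origin of this step.

Only cyclopropylcarbonyl is shown on this oxygen, so it remains open whether the shift belongs to this group or would also appear with an acetyl group, a methyl ether or an amine in place of the hydroxy. The change is also shown only with chloro on the aromatic ring, leaving open whether it reads the same on the fluoro compound 2.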